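This account rests on a few compounds, and the source may have more. Where it says the series, first, only, none or still open, it means among the compounds named here.

Measured so far:
Compound 1 `CC1(C)OB(c2ccc(COc3ccc(CNC(=O)[C@@H]4CCC(=O)N4Cc4ccccc4)cc3)cc2)OC1(C)C` — 50 nM
Compound 2 `CC1(C)OB(c2ccc(COc3ccc(CNC(=O)[C@@H]4CCC(=O)N4Cc4ccc(F)cc4)cc3)cc2)OC1(C)C` — 120 nM

Within the data shown here, in an assay on HEK293 cells for inhibition of Ataxin-2 (Mus musculus), read by fluorescence and Amplex Red (a lower number here means a stronger inhibitor, a higher number a weaker inhibitor), compound 1 gives 50 nM, the lowest of the two numbers known; its nearest neighbour is compound 2, which gives 120 nM. Among the measured compounds shown here, the one step recorded so far, a 2.4-fold higher number from compound 1 to compound 2 (0.38 log units; beyond the scatter), concerns a fluoro in place of hydrogen on an aromatic carbon, a modest change.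

Compound 3 `CC1(C)OB(c2ccc(COc3ccc(CNC(=O)[C@H]4CCC(=O)N4Cc4ccccc4)cc3)cc2)OC1(C)C` is now to be tested in this assay. It differs from compound 1 as follows: the two compounds have the same atoms and bonds and differ only in configuration as drawn: 1 of 1 stereo elements differ; a stereocentre at a saturated ring carbon is drawn S in compound 1 and R in compound 3. In words, the two compounds share every atom and bond and differ only in configuration as drawn, the stereocentre at a saturated ring carbon being S in compound 1 and R in compound 3.

For the measured compounds named here, no measured step bears on this change: the step from compound 1 to compound 2 alters a substituent, not a configuration, so it gives no guide to the size or direction of the step to compound 3. The step is expected to be a 4.0-fold higher number from compound 1 to compound 3 (0.60 log units; beyond the scatter), and this expectation is only a loose one. Inversion of a single stereocentre can leave a number unchanged or move it a good deal either way. Compound 3 is accordingly estimated at 200 nM, within a wide range from 30 nM to 1500 nM.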

Compound 3, half-maximal inhibitory concentration: 180 nM
Compound 3: middle estimate off by 1.1-fold (0.05 log units), on the high side; measured number inside the range.
By their numbers in this assay, from the lowest: compound 1; then compounds 2 and 3 (each within the scatter of the next).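

In this assay the configuration at this saturated ring carbon proves to matter, with a 3.6-fold higher number from compound 1 to compound 3 (0.56 log units; beyond the scatter) on going from S to R, a modest change but one that lies beyond the scatter. The gap can be assigned to this stereocentre alone because nothing else separates the pair: the fact that compounds 1 and 3 differ only in the configuration as drawn. Among these compounds, this is the first reading on configuration, as the earlier step, a 2.4-fold higher number from compound 1 to compound 2 (0.38 log units; beyond the scatter), concerned only a fluoro in place of hydrogen on an aromatic carbon, and it shows that the S form as drawn gives the lower number of this pair, although the inversion still leaves compound 3 at a value in the nanomolar range, 180 nM.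

Among the compounds shown here, whether the inversion has the same size and direction when the fluoro group of compound 2 is present remains open, as the single pair cannot show whether the two changes act independently. Also open, on these data alone, is how the number would respond to a chloro or methoxy group on that aromatic carbon, or to a carboxylic acid in place of the boron-bearing group.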